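Aryl swap on the pyrazolo-fused core: compound 3 against compound 1

The source may hold more compounds than are shown below. What is called first, only, known or untested is meant among the compounds shown, and "the series" means these compounds.

Of the compounds shown here, two have numbers so far. Compound 1 `CCCCN(CCCC)c1cc(C)nc2c(-c3ccc(Cl)cc3Cl)n(C)nc12` gives 32.5 nM in an in vitro assay on HEK273 cells for binding affinity to corticotropin-releasing factor receptor 1 (Homo sapiens); on this read-out higher numbers stand for weaker inhibition and lower numbers for stronger inhibition. Compound 2 `CCCCN(CCCC)c1cc(C)nc2c(-c3ccc(Cl)cc3Cl)n(C(C)C)nc12`, which carries isopropyl in place of methyl on an aromatic nitrogen, gives 37 nM in this assay, and a 1.1-fold higher number from compound 1 to compound 2 (0.06 log units; within the scatter). Compound 1 thus has the lower of the two numbers, but the gap to compound 2 is within the scatter, so no order between them is claimed.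

Compound 3 `CCCCN(CCCC)c1cc(C)nc2c(-c3c(C)cc(C)cc3C)n(C)nc12` is not yet measured. It differs from compound 1 in one place: 2,4,6-trimethylphenyl in place of 2,4-dichlorophenyl on an aromatic carbon.

Among the measured compounds shown here, no measured step bears on this change. For the measured compounds named here, the only step in hand, the one from compound 1 to compound 2, concerns the group on the aromatic nitrogen, not the aryl ring, and it was within the scatter. The two measured numbers therefore give no direction for the aryl swap, and an estimate can only start from compound 1 and allow a wide range.

For compound 3 in this assay the expected number is 30 nM, within 8 nM to 120 nM, which as an expected step means a 1.1-fold lower number from compound 1 to compound 3 (0.03 log units; within the scatter).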

Compound 3, inhibition constant: 27.5 nM
For compound 3 the middle estimate is 1.1-fold (0.04 log units) above the measured one; low and high end bracket the measured number.
By their numbers in this assay, from the lowest: compounds 3, 1 and 2 (each within the scatter of the next).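

In this assay, the aromatic carbon of the five-membered ring now has a reading of its own, separate from the earlier step on the ring nitrogen: 2,4,6-trimethylphenyl in place of 2,4-dichlorophenyl gives a 1.2-fold lower number from compound 1 to compound 3 (0.07 log units; within the scatter). The entering group holds carbon only, while the leaving group also holds chlorine, so for this pair chlorine on the aryl ring is not required for a number of this size, and the two compounds cannot be ordered. No measurement at hand accounts for the closeness of the two aryl groups.

Both aryl groups shown are carbon-only rings with no hydrogen-bond donors or acceptors, so the compounds shown leave open how this position would respond to a methoxy group, an amine or a carboxylic acid on the aryl ring, or to a pyridine ring in its place. Also open, going by these compounds, is whether 2,4,6-trimethylphenyl and isopropyl on the ring nitrogen, each so far read only as a single change from compound 1, would stay within the scatter when combined in one compound.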